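This account rests on a few compounds, and the source may have more. Where it says the series, first, only, none or still open, it means among the compounds named here.

Measured so far:
compound 1 `CCOC(=O)c1cccc(-c2ccc(N(CC)CC)nn2)c1`: > 25000 nM
compound 2 `CN1CCN(c2ccc(-c3cccc(C(F)(F)F)c3)nn2)CC1`: 50000 nM
compound 3 `CCCCOc1ccc(-c2ccc(C(=O)OCC)cc2)nn1`: > 25000 nM

All three readings come from a functional assay on Caco-2 cells (Homo sapiens) for antiproliferative activity, with a stated time of 48 h; a higher number here means a weaker inhibitor, a lower number a stronger inhibitor. For compound 1, > 25000 nM is a limit of the assay and not a number. For compound 3, > 25000 nM is likewise a limit. The set is thus marked by the limit of > 25000 nM in this assay, at which 2 of the 3 values shown sit. Among the compounds with values here, compound 2, at 50000 nM, carries the only actual number, so it cannot be ranked against the other two.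

The next compound to be read is compound 4 `FC(F)(F)c1cccc(-c2ccc(Oc3ccccc3)nn2)c1`. It takes phenoxy in place of 4-methylpiperazin-1-yl on an aromatic carbon, next to the ring nitrogen: phenoxy in place of 4-methylpiperazin-1-yl on an aromatic carbon. The rest of compound 2 stays unchanged.

Within the data shown here, no measured pair in the set differs in one place, so the size of this change in this assay has no direct precedent. With compound 2 at 50000 nM, no number in the set points to a much stronger inhibitor, and no change beyond the scatter is expected in either direction. The step of a 1.3-fold lower number from compound 2 to compound 4 (0.10 log units; within the scatter) is the expected one and is estimated to stay within the scatter. A reading that returns only a limit would fit the set equally well. For compound 4 the estimate is 40000 nM, with an expected range of 15000 nM to 100000 nM.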

Compound 4, half-maximal inhibitory concentration: > 25000 nM
Compound 4 was reported as a limit; the forecaster's own chance of this, stated with the estimate: 45%; the middle value is on the limit's open side.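

In this assay compound 4 gives > 25000 nM, which is a limit and not a number. Within the data shown here, no step can therefore be read between compound 2 and compound 4: the limit of > 25000 nM in this assay, at which 3 of the 4 values shown sit. The compounds shown leave open how phenoxy and 4-methylpiperazin-1-yl compare in this assay, and whether any change on the shared core gives a stronger inhibitor.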